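From cyclohexylamino to morpholin-4-yl on a sulfonyl sulfur

The source may report more compounds than this note shows. Statements on the series, on what has been measured and on what is new or still open speak of the compounds shown alone.

Among the measured compounds shown here, in an ADME assay on Vero cells (Chlorocebus sabaeus) for cytotoxicity, read by MTT assay (on this read-out lower numbers stand for higher toxicity in this test and higher numbers for lower toxicity in this test), compound 2 (`Cn1nc(C(F)(F)F)cc1C(=O)Nc1ccc(S(=O)(=O)NC2CCCCC2)cc1`) gives 15000 nM as the only actual number so far. Compound 1 (`Cn1nc(C(F)(F)F)cc1C(=O)Nc1ccc(S(=O)(=O)N2CCC[C@H]2C(=O)O)cc1`) stands at > 300000 nM and this value is a limit of the assay, not a number. Between the two lies an at least 20-fold lower number from compound 1 to compound 2 (1.30 log units; beyond the scatter) as a large step, with cyclohexylamino in place of 2-carboxypyrrolidin-1-yl on a sulfonyl sulfur. Compound 3 (`Cn1nc(C(F)(F)F)cc1C(=O)Nc1ccc(S(=O)(=O)N2CCOCC2)cc1`) changes the same place, with morpholin-4-yl in place of cyclohexylamino (morpholin-4-yl in place of cyclohexylamino on a sulfonyl sulfur). That one measured step is all that bears on this change. On it, a partial return towards higher numbers, meaning lower toxicity in this test, is expected, though not of the full size. The expected move is a 5.3-fold higher number from compound 2 to compound 3 (0.73 log units; beyond the scatter) and it would lie beyond the scatter. Compound 3 is estimated at 80000 nM with 25000 nM and 250000 nM as the ends of its range.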

Compound 3, half-maximal cytotoxic concentration: > 300000 nM
Compound 3: a limit, no number (the forecaster's own chance of this, stated with the estimate: 20%); middle value at least 3.7-fold (0.57 log units) from the limit.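

In this assay, compound 3 gives > 300000 nM, which is a limit of the assay and not a number. Morpholin-4-yl in place of cyclohexylamino on the sulfonyl sulfur gives an at least 20-fold higher number from compound 2 to compound 3 (1.30 log units; beyond the scatter), so reaching the limit at this position does not need the carboxylic acid of 2-carboxypyrrolidin-1-yl. The step from compound 1 to compound 3 cannot be read, and the two groups cannot be ordered: the limit of > 300000 nM in this assay, at which 2 of the 3 values shown sit.

The compounds shown leave open whether the change in this test follows the ring oxygen that morpholin-4-yl brings or the hydrogen-bond donor that cyclohexylamino takes away. A piperidin-1-yl group on the sulfonyl sulfur, with a ring lacking that oxygen and carrying no such donor, would separate the two, and an open-chain amine such as diethylamino would test whether any ring is involved.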